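The source may report more compounds than this note shows. Statements on the series, on what has been measured and on what is new or still open speak of the compounds shown alone.

Measured compounds:
Compound 1 `Cc1cccc(Cn2c(CN3CCN(C(=O)c4cccnc4)CC3)nc3ccccc32)c1` gives 24.5% in an assay on isolated protein for inhibition of aldehyde dehydrogenase 1A1 (Homo sapiens), read by spectrophotometry, tested at 10 uM; on this read-out lower numbers stand for less inhibition and higher numbers for more inhibition at the one concentration tested (going by the name of the read-out).
Compound 2 `Cc1cccc(Cn2c(CN3CCN(C(=O)c4ccc(C(C)C)cc4)CC3)nc3ccccc32)c1` gives 67.6% in this assay.

Compound 2 stands highest of the two numbers; its nearest neighbour is compound 1, and the step of a number 43.1 percentage points higher from compound 1 to compound 2 (beyond the scatter) separates them. The account now turns to compound 3 `Cc1cccc(Cn2c(CN3CCN(C(=O)c4cccs4)CC3)nc3ccccc32)c1`, which is not yet measured. The change from compound 2 to compound 3 is thiophen-2-yl in place of 4-isopropylphenyl on a carbonyl carbon.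

For the measured compounds named here, only one measured step bears on this, and only loosely: a number 43.1 percentage points higher from compound 1 to compound 2 (beyond the scatter) shows that exchanging a six-membered aromatic ring on the carbonyl carbon for another can move the read-out by a large amount. Going by the values given here, the thiophen-2-yl group is a different case again, a five-membered ring with one hetero atom, so no measured pair speaks directly to it. Among the compounds with values here, a step downward from compound 2 is expected, though smaller than the one from compound 1 to compound 2, placing compound 3 between the two measured values; the expected step is a number 25.6 percentage points lower from compound 2 to compound 3 (beyond the scatter). For compound 3 the estimated value in this assay is 42%, with a range from 20% to 65%.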

Compound 3, a percentage reported as inhibition, at one concentration (the size of the read-out at that concentration, not a potency): 60.8%
Compound 3: the middle estimate sits 18.8 percentage points below what was measured; low and high end bracket the measured number.
By their numbers in this assay, from the lowest: compound 1; then compounds 3 and 2 (each within the scatter of the next).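

In this assay, the exchange on the carbonyl carbon gives a number 6.8 percentage points lower from compound 2 to compound 3 (within the scatter), so thiophen-2-yl, with 5 heavy atoms and a sulfur in a five-membered aromatic ring, reads the same within the scatter as 4-isopropylphenyl, with 9 heavy atoms and a six-membered ring of carbon only. Pyridin-3-yl, by contrast, now stands apart from two different groups, since replacing it with thiophen-2-yl gives a number 36.3 percentage points higher from compound 1 to compound 3 (beyond the scatter), so ring size and the count of heavy atoms do not by themselves sort these three compounds, and the low number of compound 1 is tied to pyridin-3-yl alone among the groups shown. Nothing measured here accounts for why these groups read as they do.

The compounds shown leave open whether plain phenyl, furan-2-yl or pyridin-4-yl would fall with compound 1 or with compounds 2 and 3, and whether a phenyl ring carrying an amine or a carboxylic acid would still be accepted on the carbonyl carbon. They also leave open whether compounds 2 and 3, alike at one concentration, would stay alike across a full range of concentrations.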